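This account rests on a few compounds, and the source may have more. Where it says the series, first, only, none or still open, it means among the compounds named here.

Compound 3 `CC(C)n1cc2c(Cl)nc(NC(=O)c3ccc(C(F)(F)F)cc3)nc2n1` shares its core with compound 1 `CC(C)n1cc2c(Cl)nc(NC(=O)c3ccccc3)nc2n1` and compound 2 `Cn1cc2c(Cl)nc(NC(=O)c3ccc(F)cc3)nc2n1`. In a functional assay on CHO cells for antagonist activity at adenosine receptor A2b (Homo sapiens), read by 33P incorporation, with a stated time of 20 min, in the presence of a further agent that is not named here (on this read-out higher numbers stand for weaker inhibition and lower numbers for stronger inhibition), compound 3 gives > 20000 nM, which is a limit of the assay rather than a number. In this assay compound 1 gives > 20000 nM, likewise a limit. In this assay compound 2 gives > 20000 nM, again a limit. Compound 3 thus stands at the limit of > 20000 nM in this assay, at which 3 of the 3 values shown sit, with nothing that would set it apart from the other two. The step that the two limits leave unreadable from compound 1 to compound 3 cannot be read, as both of its ends are limits.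

Compound 4 `CC(C)n1cc2c(Cl)nc(NC(=O)c3ccc(F)cc3)nc2n1` differs from compound 3 by fluoro in place of trifluoromethyl on an aromatic carbon. Going by the values given here, the only measured step touching this change is the one from compound 1 to compound 3, and it gives no readable size, so no direction beyond the scatter can be expected in this assay; compound 2, which carries the same fluoro group as compound 4, also shows only a limit, making a further limit the likeliest outcome. Compound 4 is therefore estimated at 30000 nM, with a range from 12000 nM to 100000 nM. The expected step is a step that the limit leaves unreadable from compound 3 to compound 4.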

Compound 4, inhibition constant: > 20000 nM
Compound 4 ended at the assay's limit; the forecaster's own chance of this, stated with the estimate: 85%; the middle value lies beyond the limit too.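

No new step can be read from compound 4 to compound 1, compound 2 or compound 3, since all four compounds sit at one limit in this assay: the limit of > 20000 nM in this assay, at which 4 of the 4 values shown sit.

The compounds shown leave open how far beyond that limit each lies, and which change to the shared core, if any, would give a readable value.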